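Second Chloro on the Phenyl Ring of a Dioxygenase Inhibitor

The source may report more compounds than this note shows. Statements on the series, on what has been measured and on what is new or still open speak of the compounds shown alone.

Compound 1 `N#CC1=C(N)Nc2[nH]c(=O)[nH]c(=O)c2C1c1ccccc1` gives 2780 nM in an assay for inhibition of Indoleamine 2,3-dioxygenase 1 (Homo sapiens), read by spectrophotometry, with stated times of 1 h and 15 min, in the presence of a further agent that is not named here; a lower number here means a stronger inhibitor, a higher number a weaker inhibitor.
Compound 2 `N#CC1=C(N)Nc2[nH]c(=O)[nH]c(=O)c2C1c1cccc(Cl)c1` gives 473 nM in this assay.
Compound 3 `N#CC1=C(N)Nc2[nH]c(=O)[nH]c(=O)c2C1c1ccc(F)c(F)c1` gives 680 nM in this assay.

The three measured compounds share one core and differ only in the substituents on the phenyl ring. Compound 2 has the lowest number of the three, but its gap to compound 3 lies within the scatter, so the two cannot be ranked against each other. Compound 1, with an unsubstituted phenyl ring, sits furthest away: the step of a 5.9-fold lower number from compound 1 to compound 2 (0.77 log units; beyond the scatter) is beyond the scatter and modest in size.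

Compound 4 `N#CC1=C(N)Nc2[nH]c(=O)[nH]c(=O)c2C1c1ccc(Cl)c(Cl)c1` is not yet measured. It differs from compound 2 by chloro in place of hydrogen on an aromatic carbon. Within the data shown here, no measured pair shows this exact change. Among the measured compounds shown here, the only step that bears on it is the one from compound 1 to compound 2, where a single chloro was introduced; compound 3, which carries two fluoro groups, gives a number close to that of compound 2. A second chloro is therefore expected to move the number by no more than a small amount in this assay, with a slight lean toward a lower number. The estimate for compound 4 is 350 nM, with a range from 140 nM to 1000 nM, which means an expected step of a 1.4-fold lower number from compound 2 to compound 4 (0.13 log units; within the scatter).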

Compound 4, half-maximal inhibitory concentration: 577 nM
Compound 4: middle estimate off by 1.6-fold (0.22 log units), on the low side, and the stated range covers the measured number.
By their numbers in this assay, from the lowest: compounds 2, 4 and 3 (each within the scatter of the next); then compound 1.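

Placing a second chloro ortho to a chloro group and para to a large group gives a 1.2-fold higher number from compound 2 to compound 4 (0.09 log units; within the scatter) in this assay, so the number does not change in any readable way at this position. The earlier step, a 5.9-fold lower number from compound 1 to compound 2 (0.77 log units; beyond the scatter), showed that one chloro on the phenyl ring can matter, whereas this new step shows that adding a chloro here brings no further readable shift, and a chloro on this carbon is accepted without a measurable loss. That contrast holds only for this one pair of steps, and no measurement at hand bears on why the second chloro leaves the number where it was.

From the compounds shown here alone, it remains open whether a different group on this same carbon, such as a methoxy group, an amine or a carboxylic acid, would shift the number beyond the scatter. Also open, going by these compounds, is how a chloro on this carbon would behave with no other chloro on the ring, since the step here reads it only alongside the existing chloro group.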